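The source may hold more compounds than are shown below. What is called first, only, known or untested is meant among the compounds shown, and "the series" means these compounds.

In a functional assay on PC-3 cells (Homo sapiens) for antiproliferative activity, read by MTT assay, with a stated time of 48 h (on this read-out higher numbers stand for weaker inhibition and lower numbers for stronger inhibition), compound 1 `O=C(/C=C\Nc1ccc(F)cc1)c1cn(-c2ccccc2)nc1-c1ccccc1` gives 7980 nM. Compound 2 `O=C(/C=C\Nc1ccc(F)cc1)c1cn(-c2ccccc2)nc1-c1ccc(F)cc1` gives 7900 nM in this assay, and compound 3 `O=C(/C=C\Nc1ccc(O)cc1)c1cn(-c2ccccc2)nc1-c1ccc(F)cc1` gives 2600 nM. Compound 2 therefore holds the second highest of the three numbers: the step of a 1.0-fold lower number from compound 1 to compound 2 (0.00 log units; within the scatter) leaves it indistinguishable from its nearest neighbour, while the step of a 3.0-fold lower number from compound 2 to compound 3 (0.48 log units; beyond the scatter) marks the furthest gap among the three.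

Compound 4 `O=C(/C=C\Nc1ccc(F)cc1)c1cn(-c2ccccc2)nc1-c1ccc(Cl)cc1` differs from compound 2 by chloro in place of fluoro on an aromatic carbon. Within the data shown here, the only measured step at this same place is a 1.0-fold lower number from compound 1 to compound 2 (0.00 log units; within the scatter), in which a fluoro entering the ring did not move the number. The step of a 3.0-fold lower number from compound 2 to compound 3 (0.48 log units; beyond the scatter) concerns a hydroxy in place of fluoro, a different kind of exchange, and bears only loosely on the present one. On that basis no step beyond the scatter is expected for compound 4, an expectation expressed as a 1.1-fold lower number from compound 2 to compound 4 (0.02 log units; within the scatter). Compound 4 is accordingly estimated at 7500 nM, with a range from 3500 nM to 16000 nM.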

Compound 4, half-maximal inhibitory concentration: > 50000 nM
Compound 4: a limit, no number (the forecaster's own chance of this, stated with the estimate: 5%); middle value at least 6.6-fold (0.82 log units) away from the limit.
By their numbers in this assay, from the lowest: compound 3; then compounds 2 and 1 (each within the scatter of the next). At a limit, above all of these: compound 4.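

Among these compounds, at this place, on an aromatic carbon para to a large group, the earlier compounds showed only that hydrogen and fluoro could not be told apart. Chloro proves different from both: chloro in place of fluoro gives an at least 6.3-fold higher number from compound 2 to compound 4 (0.80 log units; beyond the scatter), and chloro in place of hydrogen gives an at least 6.2-fold higher number from compound 1 to compound 4 (0.79 log units; beyond the scatter), so this place does respond to the group it carries, and a change of a single atom is enough. The result for compound 4 in this assay is a limit and not a number: the limit of > 50000 nM in this assay, at which 1 of the 4 values shown sits.

On these data alone, how far compound 4 lies past that limit stays open, so the true size of both steps is unknown. Also open, as far as these compounds go, is whether a bromo, a methyl, a methoxy or an amine at this place would behave like fluoro or like chloro.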